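Working notes: from compound 3 to compound 4

The source may report more compounds than this note shows. Statements on the series, on what has been measured and on what is new or still open speak of the compounds shown alone.

Measured in a functional assay on B16 cells (Mus musculus) for cytotoxicity, read by CCK-8 assay, with a stated time of 24 h (on this read-out higher numbers stand for weaker inhibition and lower numbers for stronger inhibition), so far
- compound 1 `COc1ccccc1Oc1c(N)nc(-c2cccc(C)c2)nc1OCCO` gives 70900 nM
- compound 2 `COc1ccccc1Oc1c(N)nc(-c2ccccc2F)nc1OCCO` gives 11800 nM
- compound 3 `COc1ccccc1Oc1c(N)nc(-c2cccc(F)c2)nc1OCCO` gives 20900 nM

In this assay compound 3 holds the second highest of the three numbers. It lies within the scatter of compound 2 and beyond the scatter of compound 1. Compound 4 `COc1ccccc1Oc1c(N)nc(-c2ccc(Br)cc2)nc1OCCO` carries 4-bromophenyl in place of 3-fluorophenyl on an aromatic carbon between two ring nitrogen atoms (4-bromophenyl in place of 3-fluorophenyl on an aromatic carbon). Among the compounds with values here, two measured steps bear on this change. Exchanging 2-fluorophenyl for 3-fluorophenyl stayed within the scatter (a 1.8-fold higher number from compound 2 to compound 3 (0.25 log units; within the scatter)), while fluoro in place of methyl gave a modest step (a 3.4-fold lower number from compound 1 to compound 3 (0.53 log units; beyond the scatter)). Within the data shown here, no measured compound carries a bromo group, so the direction remains open and the range must be wide. With that caveat, no step beyond the scatter is expected (a 1.2-fold higher number from compound 3 to compound 4 (0.08 log units; within the scatter)). Compound 4 is estimated at 25000 nM (range 9000 nM to 70000 nM).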

Compound 4, half-maximal inhibitory concentration: 11800 nM
Estimate against measurement, compound 4: 2.1-fold (0.33 log units) above; measured number inside the range.
By their numbers in this assay, from the lowest: compounds 2, 4 and 3 (each within the scatter of the next); then compound 1.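

Placing bromine at the far end of the ring does not separate this position from the fluorophenyl compounds in this assay (a 1.8-fold lower number from compound 3 to compound 4 (0.25 log units; within the scatter); no change at the digits printed from compound 2 to compound 4 (within the scatter)), so a larger halogen and a different ring position are both accommodated here without a step beyond the scatter. Against the 3-methylphenyl group the change is beyond the scatter (a 6.0-fold lower number from compound 1 to compound 4 (0.78 log units; beyond the scatter)), leaving compound 1 apart from the three halogen-bearing compounds 2, 3 and 4. No measured evidence accounts for these numbers.

In compound 4 the halogen and its ring position change together, so their contributions remain unseparated. As far as these compounds go, how an amine or a carboxylic acid on this phenyl ring would read stays open, as does a longer chain in place of the 2-hydroxyethoxy group.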